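From compound 3 to compound 4: removing one methoxy

The compounds below may be only part of what the source reports. "The series", "measured", "known", "first", "only" and "open" are said of these compounds alone.

Measured in a functional assay on A549 cells (Homo sapiens) for antiproliferative activity, read by MTT assay, with a stated time of 48 h; on this read-out lower numbers stand for stronger inhibition and higher numbers for weaker inhibition:
- compound 1 `COc1ccc(-c2nn(-c3ccccc3)cc2C(Nc2nc3ccccc3s2)c2c(O)ccc3ccccc23)cc1`: 26200 nM
- compound 2 `Cc1ccc(-c2nn(-c3ccccc3)cc2C(Nc2nc3ccccc3s2)c2c(O)ccc3ccccc23)cc1`: 57400 nM
- compound 3 `COc1ccc(-c2nn(-c3ccccc3)cc2C(Nc2nc3ccc(OC)cc3s2)c2c(O)ccc3ccccc23)cc1`: 28100 nM

In this assay, compound 3 gives 28100 nM, which lies within the scatter of compound 1. Compound 2 shows a higher number, and that gap from compound 3 is beyond the scatter. All three numbers point to weak inhibition of cell growth.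

The next compound is compound 4 `COc1ccc2nc(NC(c3cn(-c4ccccc4)nc3-c3ccccc3)c3c(O)ccc4ccccc34)sc2c1`, which has not yet been measured. Its difference from compound 3 is hydrogen in place of methoxy on an aromatic carbon. In words, this is hydrogen in place of methoxy on an aromatic carbon, turning 4-methoxyphenyl into phenyl.

The closest measured evidence is a 2.2-fold higher number from compound 1 to compound 2 (0.34 log units; beyond the scatter), where methyl replaces this same methoxy. Among the measured compounds shown here, that step is modest, and no measured compound carries hydrogen at this place. The other measured step, a 1.1-fold higher number from compound 1 to compound 3 (0.03 log units; within the scatter), concerns a different methoxy, which stays in place here, so it says little about this change.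

A modest rise in the number, meaning somewhat weaker inhibition, is therefore expected in this assay. The expected change is a 1.6-fold higher number from compound 3 to compound 4 (0.20 log units; within the scatter). For compound 4, the estimated value is 45000 nM, with an expected range of 20000 nM to 100000 nM.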

Compound 4, half-maximal inhibitory concentration: 44600 nM
The estimate for compound 4 lay 1.0-fold (0.00 log units) above the measured number; the range from low to high includes it.
By their numbers in this assay, from the lowest: compounds 1, 3, 4 and 2 (each within the scatter of the next, the first and the last beyond it).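

With hydrogen in place of the methoxy, turning 4-methoxyphenyl into phenyl, this assay gives a step that stays within the usual scatter (a 1.6-fold higher number from compound 3 to compound 4 (0.20 log units; within the scatter)), so on this evidence the two compounds cannot be told apart. Among the compounds shown here, this is the first reading with no substituent at this place, and it shows that, with the other methoxy kept on the core, the methoxy on this ring can go without a change that the assay can resolve. The earlier step at the same place (a 2.2-fold higher number from compound 1 to compound 2 (0.34 log units; beyond the scatter)) put a methyl there, in compounds without that other methoxy, so it differs from the new step in both the incoming group and the surroundings, and no measurement shown bears on what lies behind the new result.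

The compounds shown leave open whether hydrogen at this place would give a similar result in a compound lacking the other methoxy. They also leave open whether a different group on this ring, such as an amine, a carboxylic acid or a longer chain, would move the number clearly away from this weak range.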